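A few compounds are considered here, and "the series" means these few. Any claim that something is new, unique, unknown or untested is made for them only; others in the source may bear on it.

Working notes on the series. Compound 1 `NC1=NC2(CCOCC2)N(OCCCOc2cccc(Cl)c2)C(N)=N1` has no result in an assay on isolated protein for inhibition of Dihydrofolate reductase (Homo sapiens), read by spectrophotometry, using NADPH, with stated times of 5 s and 6 min; a higher number here means a weaker inhibitor, a lower number a stronger inhibitor; its entry reads "not determined" (no result reported). Among the measured compounds shown here, compound 2 `NC1=NC2(CCOCC2)N(OCCCOc2ccc(F)cc2)C(N)=N1` is therefore the one member with a number: in this assay compound 2 gives 46.6 nM, and with nothing else measured it cannot be placed as stronger or weaker than any neighbour. Compound 3 `NC1=NC2(CCOCC2)N(OCCCOc2cc(Cl)c(Cl)cc2Cl)C(N)=N1` is the next member to be measured. It differs from compound 2 in one place, counted as 2,4,5-trichlorophenyl in place of 4-fluorophenyl on an oxygen on a saturated carbon. For the measured compounds named here, no step between two measured compounds has been recorded, so the size of this change can only be estimated. The expectation is a modest step toward a stronger inhibitor, estimated as a 2.3-fold lower number from compound 2 to compound 3 (0.37 log units; beyond the scatter), which may or may not exceed the usual scatter. Compound 3 is accordingly expected to give about 20 nM in this assay, within a range from 5 nM to 90 nM.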

Compound 3, half-maximal inhibitory concentration: 36 nM
Compound 3: middle estimate off by 1.8-fold (0.26 log units), on the low side; low and high end bracket the measured number.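

In this assay, among the compounds shown here, the first readable step at this position is small: 2,4,5-trichlorophenyl in place of 4-fluorophenyl on an oxygen on a saturated carbon gives a 1.3-fold lower number from compound 2 to compound 3 (0.11 log units; within the scatter), so the two compounds cannot be told apart in this read-out. At this position, then, the two substituted phenyl groups give values of the same level, and the change in halogen and in heavy-atom count leaves no measurable mark. Nothing available bears on why the two values match.

Steps involving compound 1 cannot be read, so the chlorophenyl group it carries remains unplaced against the other two. Also open, on these data alone, is whether a phenyl ring bearing an amine or a carboxylic acid, or a longer chain to the oxygen, would depart from this level.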